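The compounds below may be only part of what the source reports. "The series", "measured", "known", "first", "only" and "open" are said of these compounds alone.

Working notes on the series in a functional assay on MCF7 cells (Homo sapiens) for inhibition, read by MTT assay, with a stated time of 72 h; a higher number here means a weaker inhibitor, a lower number a stronger inhibitor. Compound 1 (`COc1cc2c(Oc3ccc(NC(=O)c4nn(-c5ccccc5C)cc(C)c4=O)cc3)ccnc2cc1OCC(=O)NO`) gives 8780 nM, compound 2 (`COc1cc2c(Oc3ccc(NC(=O)c4nn(-c5ccccc5)cc(C)c4=O)cc3)ccnc2cc1OCCCCCCC(=O)NO`) gives 1610 nM and compound 3 (`COc1cc2c(Oc3ccc(NC(=O)c4nn(-c5ccccc5C)cc(C)c4=O)cc3)ccnc2cc1OCCCCCCC(=O)NO`) gives 1830 nM. Compound 3 holds the middle of these three numbers, though its gap to compound 2 lies within the scatter, and compound 1 stands clearly higher: a 4.8-fold lower number from compound 1 to compound 3 (0.68 log units; beyond the scatter).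

Compound 4 (`COc1cc2c(Oc3ccc(NC(=O)c4nn(-c5ccc(F)c(Cl)c5)cc(C)c4=O)cc3)ccnc2cc1OCCCCCCC(=O)NO`) differs from compound 3 at one place: 3-chloro-4-fluorophenyl in place of 2-methylphenyl on an aromatic nitrogen. In words, 3-chloro-4-fluorophenyl stands in place of 2-methylphenyl on an aromatic nitrogen. Among the measured compounds shown here, only one measured step touches this group, the addition of the methyl that separates compound 2 from compound 3: a 1.1-fold higher number from compound 2 to compound 3 (0.06 log units; within the scatter). The larger step, from compound 1 to compound 3, concerns the 5-(hydroxycarbamoyl)pentyl chain, which compound 3 and compound 4 both carry, so it offers no guide here. For the measured compounds named here, no measured compound carries chlorine or fluorine, so the effect of these two atoms is unknown. With compound 3 and compound 2 showing no separation at a 1.1-fold higher number from compound 2 to compound 3 (0.06 log units; within the scatter), no step beyond the scatter is expected in this assay. The expected step is a 1.2-fold lower number from compound 3 to compound 4 (0.09 log units; within the scatter). Compound 4 is estimated at 1500 nM, with an expected range of 700 nM to 3200 nM.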

Compound 4, half-maximal inhibitory concentration: 2200 nM
The estimate for compound 4 lay 1.5-fold (0.17 log units) below the measured number, within the range that was stated.
By their numbers in this assay, from the lowest: compounds 2, 3 and 4 (each within the scatter of the next); then compound 1.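

In this assay, replacing 2-methylphenyl with 3-chloro-4-fluorophenyl on the aromatic nitrogen stays within the scatter (a 1.2-fold higher number from compound 3 to compound 4 (0.08 log units; within the scatter)), as does replacing phenyl with the same group (a 1.4-fold higher number from compound 2 to compound 4 (0.14 log units; within the scatter)). The earlier compounds shown here tested this position only by adding a methyl; it now also takes a larger, doubly halogenated phenyl, with one more heavy atom than 2-methylphenyl, and compound 2, compound 3 and compound 4 remain unseparated while all carrying the 5-(hydroxycarbamoyl)pentyl chain. Nothing at hand bears on why these numbers stay together.

Still open, on these data alone, is whether any group at this position can move the number beyond the scatter, for example a phenyl carrying an amine or a carboxylic acid, a pyridyl ring in place of the phenyl, or a phenyl with chlorine alone or fluorine alone. As far as these compounds go, it is also open whether 3-chloro-4-fluorophenyl would behave the same way with the hydroxycarbamoyl group of compound 1 or with a longer chain than 5-(hydroxycarbamoyl)pentyl.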